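Trading Benzyloxy for (4-Fluorophenyl)amino at the Assay's Limit

The compounds below may be only part of what the source reports. "The series", "measured", "known", "first", "only" and "open" are said of these compounds alone.

Compound 1 (`C=C[C@@](C)(/C=C/c1ccc(OCc2ccccc2)cc1)CCC=C(C)C`) is the starting point for this step, and it offers no exact number. In a functional assay on Raji cells (Homo sapiens) for cytotoxicity, with a stated time of 72 h (a lower number here means that less compound is needed, a higher number that more compound is needed for the effect), compound 1 gives > 26000 nM as a limit and not a measured value. Compound 2 (`C=C[C@@](C)(/C=C/c1ccc(O)c(/C=C/C(=O)OCc2ccccc2)c1)CCC=C(C)C`) gives > 26000 nM and this too is a limit. Compound 3 (`CC(C)=CCC[C@@](C)(/C=C/c1ccccc1)/C=C/c1ccc(O)cc1`) gives > 26000 nM and this is likewise a limit. So the limit of > 26000 nM in this assay, at which 3 of the 3 values shown sit, is all that the series shows so far, and the three compounds cannot be ranked against one another.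

Compound 4 (`C=C[C@@](C)(/C=C/c1ccc(Nc2ccc(F)cc2)cc1)CCC=C(C)C`) carries (4-fluorophenyl)amino in place of benzyloxy on an aromatic carbon, para to a large group ((4-fluorophenyl)amino in place of benzyloxy on an aromatic carbon). Within the data shown here, no measured pair shows what such a replacement does, so any forecast is loose. Only a modest step is expected, toward a lower number in this assay if it moves at all, and compound 4 may well report only a limit as the others do. The expected change is an at least 1.5-fold lower number from compound 1 to compound 4 (0.18 log units; that floor lies within the scatter) on this reading, with wide uncertainty. In this assay compound 4 is estimated at 17000 nM and expected to fall between 6000 nM and 30000 nM.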

Compound 4, half-maximal effective concentration: > 26000 nM
Compound 4: a limit, no number; the forecaster's own chance of this, stated with the estimate: 50%; middle value at least 1.5-fold (0.18 log units) away from the limit.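

In this assay compound 4 gives > 26000 nM, which is a limit and not a number. Compound 1 also stands at a limit, so no step can be read from compound 1 to compound 4. The compounds shown leave open how (4-fluorophenyl)amino compares with benzyloxy on the shared core, since the series still offers only one result: the limit of > 26000 nM in this assay, at which 4 of the 4 values shown sit.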